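The compounds below may be only part of what the source reports. "The series", "measured", "known", "first", "only" and "open" are said of these compounds alone.

Inhibition of swelling in the rat paw was measured in a functional assay on the whole organism (strain albino) for inhibition, with Rattus norvegicus as the target, read by paw edema, with stated times of 30 min and 1 h, at a dose of 100 mg/kg by the oral route; a lower number here means less inhibition, a higher number more inhibition at the dose given (going by the name of the read-out). Going by the values given here, compound 2, `CC(O[N+](=O)[O-])C(=O)Nc1ccc(C(=O)/C=C/c2ccc(Cl)cc2)cc1`, gives the higher of the two numbers known so far, with 45% in this assay. Among the compounds with values here, compound 1, `COc1ccc(/C=C/C(=O)c2ccc(NC(=O)CO[N+](=O)[O-])cc2)cc1`, gives 33%, a lower value, and the gap between the two is beyond the usual scatter; these two compounds differ in more than one place, so only the pair of values itself can be read.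

Compound 3, `COc1ccc(/C=C/C(=O)c2ccc(NC(=O)C(C)O[N+](=O)[O-])cc2)cc1`, has not yet been measured. It differs from compound 2 in one place: methoxy in place of chloro on an aromatic carbon.

Within the data shown here, no single-change step between measured compounds is available to guide the size of this change. On the two values known, the step of a number 8 percentage points lower from compound 2 to compound 3 (within the scatter) is expected to be a modest decrease, near the edge of the scatter. Compound 3 is accordingly estimated at 37%, within 25% to 49%.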

Compound 3, a percentage reported as inhibition, in the whole organism at one dose (the size of the read-out at that dose, not a potency): 43%
For compound 3 the middle estimate is 6 percentage points below the measured one; measured number inside the range.
By their numbers in this assay, from the lowest: compounds 1, 3 and 2 (each within the scatter of the next, the first and the last beyond it).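

In this assay, the change from 4-chlorophenyl to 4-methoxyphenyl, on an aromatic carbon para to a large group, gives a number 2 percentage points lower from compound 2 to compound 3 (within the scatter), so chloro and methoxy cannot be told apart at this position. The second single change, methyl in place of hydrogen on the saturated chain carbon, gives a number 10 percentage points higher from compound 1 to compound 3 (within the scatter), so that change cannot be separated from the usual scatter either. Nothing available explains either result.

From the compounds shown here alone, it remains open whether a quite different group at this aromatic position, such as an amine, a carboxylic acid or a nitrile, would give a number clearly apart from those of chloro and methoxy. Going by these compounds, it is equally open whether a longer chain, such as ethyl in place of the methyl, would shift the number beyond the scatter.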